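Phenyl to chloropyrimidine on the amine nitrogen of compound 2

This account rests on a few compounds, and the source may have more. Where it says the series, first, only, none or still open, it means among the compounds named here.

Compound 1 (`C[C@@H](Cn1ccc(-c2ccc(C#N)c(Cl)c2)n1)NC(=O)C1CC(=O)C1`): > 30000 nM (a limit)
Compound 2 (`C[C@@H](Cn1ccc(-c2ccc(C#N)c(Cl)c2)n1)Nc1ccccc1`): 3210 nM

Going by the values given here, in an ADME assay on PC-3 cells (Homo sapiens) for cytotoxicity, read by CCK-8 assay, with a stated time of 6 days (a higher number here means a weaker inhibitor, a lower number a stronger inhibitor), compound 2 holds the only actual number (3210 nM). Compound 1 gives only a limit (> 30000 nM). Compound 3 (`C[C@@H](Cn1ccc(-c2ccc(C#N)c(Cl)c2)n1)Nc1nccc(Cl)n1`) carries 4-chloropyrimidin-2-yl in place of phenyl on an amine nitrogen. Among the compounds with values here, one measured step bears on this nitrogen (an at least 9.3-fold lower number from compound 1 to compound 2 (0.97 log units; beyond the scatter)), and it rests on a limit (the limit of > 30000 nM in this assay, at which 1 of the 2 values shown sits). That step shows the group here can move the number, but it concerns a different group and gives no direction for this change. No shift beyond the scatter is expected (a 1.1-fold lower number from compound 2 to compound 3 (0.03 log units; within the scatter)), though with a wide margin. For compound 3 the estimated value is 3000 nM, expected to fall between 900 nM and 12000 nM.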

Compound 3, half-maximal inhibitory concentration: > 30000 nM
Compound 3 was reported as a limit; the forecaster's own chance of this, stated with the estimate: 8%; at least 10-fold (1.00 log units) between middle value and limit.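

In this assay, 4-chloropyrimidin-2-yl in place of phenyl on the amine nitrogen gives an at least 9.3-fold higher number from compound 2 to compound 3 (0.97 log units; beyond the scatter), so an aromatic ring on this nitrogen does not by itself preserve the number of compound 2. Compound 3 gives only a limit, > 30000 nM. Phenyl is thus the only group on this nitrogen in the series with an actual number: the limit of > 30000 nM in this assay, at which 2 of the 3 values shown sit.

The step between compound 1 and compound 3 cannot be read. Going by these compounds, whether the change tracks the ring nitrogens or the chlorine stays open, and a chlorophenyl or an unsubstituted pyrimidinyl on this nitrogen would separate the two.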